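Isopropoxy in Place of Chloro: What to Expect for Compound 4

The compounds below may be only part of what the source reports. "The series", "measured", "known", "first", "only" and "open" are said of these compounds alone.

Three compounds have been measured in a functional assay on Jurkat cells (Homo sapiens) for activation, with a stated time of 24 h; a higher number here means that more compound is needed for the effect, a lower number that less compound is needed:
compound 1, `Oc1ccccc1CNc1ccc(-c2ccc(Cl)cc2)cc1`, gives 2390 nM;
compound 2, `Oc1ccccc1CNc1ccc(-c2ccccc2F)cc1`, gives 2150 nM;
compound 3, `Oc1ccccc1CNc1ccc(C2CCCCC2)cc1`, gives 8800 nM.

Compound 1 stands second highest of the three. Its nearest neighbour is compound 2, with a 1.1-fold lower number from compound 1 to compound 2 (0.05 log units; within the scatter); its furthest is compound 3, with a 3.7-fold higher number from compound 1 to compound 3 (0.57 log units; beyond the scatter). Compound 4, `CC(C)Oc1ccc(-c2ccc(NCc3ccccc3O)cc2)cc1`, differs from compound 1 in one place: isopropoxy in place of chloro on an aromatic carbon.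

Two kinds of step bear on this. Swapping one substituted aryl for another gave a 1.1-fold lower number from compound 1 to compound 2 (0.05 log units; within the scatter), within the scatter. Replacing the aryl by cyclohexyl gave a 3.7-fold higher number from compound 1 to compound 3 (0.57 log units; beyond the scatter) and a 4.1-fold higher number from compound 2 to compound 3 (0.61 log units; beyond the scatter), both modest. Compound 4 keeps the aryl and only changes its substituent, so a step within the scatter is expected: a 1.0-fold higher number from compound 1 to compound 4 (0.02 log units; within the scatter). Compound 4 is therefore estimated at 2500 nM, with a range from 900 nM to 7000 nM.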

Compound 4, half-maximal effective concentration: 5940 nM
Compound 4: the middle estimate sits 2.4-fold (0.38 log units) below what was measured; the measured number falls inside the stated range.
By their numbers in this assay, from the lowest: compounds 2 and 1 (each within the scatter of the next); then compounds 4 and 3 (each within the scatter of the next).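

The step to isopropoxy, a 2.5-fold higher number from compound 1 to compound 4 (0.40 log units; beyond the scatter), shows that in this assay this aromatic carbon responds to its substituent even with the aryl kept, whereas the aryl swap, a 1.1-fold lower number from compound 1 to compound 2 (0.05 log units; within the scatter), had left the number unchanged within the scatter. The step is modest, and it goes in the direction of a higher number. Nothing measured here accounts for it.

As far as these compounds go, whether the shift tracks the four heavy atoms of isopropoxy or its oxygen remains open. A methoxy, an ethyl or an amine on the same carbon would help separate these readings.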